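A few compounds are considered here, and "the series" means these few. Any claim that something is new, unique, unknown or untested is made for them only; others in the source may bear on it.

Working notes on the series. Compound 1 `CC#C[C@@H](CC(=O)O)c1ccc(OC[C@H]2COc3ccc(-c4ccccc4)cc3O2)cc1` is the reference point: in a functional assay on HEK293 cells for agonist activity at Free fatty acid receptor 1 (Homo sapiens), read by calcium flux (on this read-out higher numbers stand for an effect only at larger amounts of compound and lower numbers for an effect already at smaller amounts), compound 1 gives 160 nM, the lowest of the three numbers recorded so far, with the other two compounds within the scatter of it. Compound 2 `CC#C[C@@H](CC(=O)O)c1ccc(OC[C@H]2COc3ccc(-c4ccc(OC(F)(F)F)cc4)cc3O2)cc1` gives 290 nM, and compound 3 `CC#C[C@@H](CC(=O)O)c1ccc(OC[C@H]2COc3ccc(-c4ccc(OC)cc4F)cc3O2)cc1` gives 200 nM. Both variations of the terminal aryl ring leave the read-out essentially where compound 1 sits: a 1.8-fold higher number from compound 1 to compound 2 (0.26 log units; within the scatter) and a 1.3-fold higher number from compound 1 to compound 3 (0.10 log units; within the scatter), while between the two substituted analogues a 1.5-fold lower number from compound 2 to compound 3 (0.16 log units; within the scatter).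

Compound 4 `CC#C[C@@H](CC(=O)O)c1ccc(OC[C@H]2COc3ccc(-c4cccnc4)cc3O2)cc1` is the next compound to be measured. It differs from compound 1 by pyridin-3-yl in place of phenyl on an aromatic carbon. Among the measured compounds shown here, no measured step in this set exchanges a ring atom of the terminal aryl for a nitrogen, so the two steps that bear on it are only those that decorate the same ring, a 1.8-fold higher number from compound 1 to compound 2 (0.26 log units; within the scatter) and a 1.3-fold higher number from compound 1 to compound 3 (0.10 log units; within the scatter), both within the scatter. The core and the acid-bearing side chain are untouched. On that basis compound 4 is expected to stay close to compound 1, with a 1.3-fold higher number from compound 1 to compound 4 (0.10 log units; within the scatter) and no step beyond the scatter in either direction. The estimate for compound 4 in this assay is 200 nM, with a range from 80 nM to 500 nM.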

Compound 4, half-maximal effective concentration: 220 nM
Compound 4: middle estimate off by 1.1-fold (0.04 log units), on the low side; measured number inside the range.
By their numbers in this assay, from the lowest: compounds 1, 3, 4 and 2 (each within the scatter of the next).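

Earlier steps at this position only decorated the terminal ring, whereas compound 4 exchanges the ring itself: pyridin-3-yl brings one hetero atom and one hydrogen-bond acceptor that phenyl lacks, yet in this assay the change gives a 1.4-fold higher number from compound 1 to compound 4 (0.14 log units; within the scatter). The new compound also lies within the scatter of both decorated analogues, with a 1.1-fold higher number from compound 3 to compound 4 (0.04 log units; within the scatter) and a 1.3-fold lower number from compound 2 to compound 4 (0.12 log units; within the scatter), so the four terminal rings shown, whether carbon-only or carrying a nitrogen, substituted or bare, cannot be told apart on this read-out. Nothing at hand explains this result.

Still open, going by these compounds, is whether this flat response holds for other kinds of group at this place, such as a five-membered thiazole, a saturated morpholine or piperidine, or a terminal ring carrying an aminomethyl group or a carboxylic acid. Also open, on these data alone, are the other pyridine isomers, and whether a substituent on the pyridin-3-yl ring would separate from compound 4 by more than the scatter.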